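The source may hold more compounds than are shown below. What is called first, only, known or untested is meant among the compounds shown, and "the series" means these compounds.

In a functional assay on MKN-45 cells (Homo sapiens) for antiproliferative activity (on this read-out lower numbers stand for stronger inhibition and higher numbers for weaker inhibition), compound 1 (`COc1ccc(S(=O)(=O)N2CCc3cccc(Nc4ccccc4)c32)cc1`), with a phenyl on the nitrogen, gives 187 nM. Fluorinated compound 2 (`COc1ccc(S(=O)(=O)N2CCc3cccc(Nc4ccc(F)cc4)c32)cc1`) gives 563 nM, and compound 3 (`COc1ccc(S(=O)(=O)N2CCc3cccc(Nc4ccc(F)c(F)c4)c32)cc1`) gives 726 nM. Compound 3 therefore sits level with compound 2, the measured gap being a 1.3-fold higher number from compound 2 to compound 3 (0.11 log units; within the scatter). Both lie on the weaker side of compound 1, and the gap for compound 3 is a 3.9-fold higher number from compound 1 to compound 3 (0.59 log units; beyond the scatter).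

Compound 4 (`COc1ccc(S(=O)(=O)N2CCc3cccc(Nc4ccc([N+](=O)[O-])cc4)c32)cc1`) carries 4-nitrophenyl in place of 3,4-difluorophenyl on a nitrogen on an aromatic ring. Within the data shown here, no compound with this group has been measured, so the available guidance is indirect. The first fluoro gave a modest step, a 3.0-fold higher number from compound 1 to compound 2 (0.48 log units; beyond the scatter), and the second added nothing beyond the scatter, as the gap between compound 2 and compound 3 shows. Both substituted compounds moved the same way from the unsubstituted phenyl of compound 1, but two compounds make a thin basis, and neither carries the incoming group. Compound 4 is therefore expected to stay close to compound 3, with no step beyond the scatter in this assay, and the range is kept wide. The expected step is a 1.2-fold lower number from compound 3 to compound 4 (0.08 log units; within the scatter). For compound 4 the estimated value is 600 nM, with an expected range of 180 nM to 2000 nM.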

Compound 4, half-maximal inhibitory concentration: 107 nM
Compound 4: middle estimate off by 5.6-fold (0.75 log units), on the high side, and the stated range ends above it.
By their numbers in this assay, from the lowest: compounds 4 and 1 (each within the scatter of the next); then compounds 2 and 3 (each within the scatter of the next).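

At the group on the nitrogen, this assay does not lose ground with every substituent on the phenyl: nitro in place of fluoro on an aromatic carbon gives a 5.3-fold lower number from compound 2 to compound 4 (0.72 log units; beyond the scatter) and 4-nitrophenyl in place of 3,4-difluorophenyl gives a 6.8-fold lower number from compound 3 to compound 4 (0.83 log units; beyond the scatter) in a series where only fluorinated rings had been seen to differ from the phenyl. Nitro in place of hydrogen gives a 1.7-fold lower number from compound 1 to compound 4 (0.24 log units; within the scatter) and so leaves compound 4 level with compound 1, while compounds 2 and 3 stay on the weaker side, which means the outcome at this ring depends on which group enters and not merely on whether one enters. No measurement at hand explains why the nitro and fluoro compounds part in this way.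

Open, from the compounds shown here alone, is whether an amine, a nitrile or a carboxylic acid in place of the nitro would sit with compounds 1 and 4 or with compounds 2 and 3. Going by these compounds, with one nitro compound and two fluoro compounds, it also remains open whether a methoxy or a trifluoromethyl group would extend the result in this assay or whether compound 4 stands alone.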